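The compounds below may be only part of what the source reports. "The series", "measured", "known", "first", "only" and "open" are said of these compounds alone.

Compound 3 `CCCS(=O)(=O)Nc1ccc(F)c(C(=O)c2n[nH]c3ncc(-c4ccc(C(C)(C)C)cc4)cc23)c1F` carries a 4-(tert-butyl)phenyl group on the shared core. Among the measured compounds shown here, in an assay for binding affinity to dual specificity mitogen-activated protein kinase kinase 4 (Homo sapiens), read by KINOMEscan, tested at 100 nM (on this read-out lower numbers stand for a stronger effect and higher numbers for a weaker effect at the one concentration tested), compound 3 gives 46%, the second highest of the three numbers so far. Compound 1 `CCCS(=O)(=O)Nc1ccc(F)c(C(=O)c2n[nH]c3ncc(-c4ccccc4OC)cc23)c1F` gives 1.9% in this assay, and compound 2 `CCCS(=O)(=O)Nc1ccc(F)c(C(=O)c2n[nH]c3ncc(-c4cc(Cl)cc(Cl)c4)cc23)c1F` gives 73%. The step of a number 44.1 percentage points higher from compound 1 to compound 3 (beyond the scatter) and the step of a number 27 percentage points lower from compound 2 to compound 3 (beyond the scatter) place compound 3 between the other two, and the step of a number 71.1 percentage points higher from compound 1 to compound 2 (beyond the scatter) is the widest spread in the set, so the aryl group at this position moves the read-out over most of its range among these three compounds.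

Compound 4 `CCCS(=O)(=O)Nc1ccc(F)c(C(=O)c2n[nH]c3ncc(-c4ccc(S(N)(=O)=O)cc4Cl)cc23)c1F` differs from compound 3 in one place: 2-chloro-4-sulfamoylphenyl in place of 4-(tert-butyl)phenyl on an aromatic carbon. For the measured compounds named here, the steps that bear on this are a number 44.1 percentage points higher from compound 1 to compound 3 (beyond the scatter) and a number 27 percentage points lower from compound 2 to compound 3 (beyond the scatter), both exchanges of the same aryl group. The 2-methoxyphenyl of compound 1 gives the lowest number and the 3,5-dichlorophenyl of compound 2 the highest; the 2-chloro-4-sulfamoylphenyl of compound 4 shares a chlorine with compound 2 but brings hydrogen-bond donor and acceptor atoms absent from every measured compound. A step of uncertain direction in this assay is therefore expected, most likely downward but with a wide range. Compound 4 is expected to give 30%, between 5% and 75%. This corresponds to an expected step of a number 16 percentage points lower from compound 3 to compound 4 (beyond the scatter).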

Compound 4, a percentage reported as activity, at one concentration (the size of the read-out at that concentration, not a potency): 3.4%
Compound 4: the middle estimate sits 26.6 percentage points above what was measured; the whole stated range lies above it.
By their numbers in this assay, from the lowest: compounds 1 and 4 (each within the scatter of the next); then compound 3; then compound 2.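

In this assay, the 2-chloro-4-sulfamoylphenyl group gives a number 42.6 percentage points lower from compound 3 to compound 4 (beyond the scatter) and a number 69.6 percentage points lower from compound 2 to compound 4 (beyond the scatter), so a chlorine shared with the 3,5-dichlorophenyl group does not by itself bring a high number at this position. The step of a number 1.5 percentage points higher from compound 1 to compound 4 (within the scatter) places two differently substituted aryl groups together at the low end of the read-out, and among these four compounds, with none going against it, the two groups named with a substituent at the 2 position, 2-methoxyphenyl and 2-chloro-4-sulfamoylphenyl, give the low numbers, while 4-(tert-butyl)phenyl and 3,5-dichlorophenyl give the higher ones. No evidence at hand accounts for the size of this exchange.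

Open, from the compounds shown here alone, is how a plain 2-chlorophenyl group and a 4-sulfamoylphenyl group would each read, which would separate the share of the chlorine from that of the sulfamoyl group. Also open, going by these compounds, is whether the low numbers hold with other groups at the 2 position, such as an amine or a carboxylic acid.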